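Swapping Cyclohexyl for Fluoro in a Weak Inhibitor

The compounds below may be only part of what the source reports. "The series", "measured", "known", "first", "only" and "open" are said of these compounds alone.

In a functional assay (Homo sapiens) for inhibition (a higher number here means a weaker inhibitor, a lower number a stronger inhibitor), compound 1 `O=C(/C=C/c1ccc(Oc2ccccc2)cc1)c1ccc(F)cc1` gives 33000 nM and compound 2 `O=C(/C=C/c1ccc(F)cc1)c1ccc(C2CCCCC2)cc1` gives 74000 nM as the concentration needed for half-maximal inhibition. Compound 2 therefore holds the higher of the two numbers, which makes it the weaker inhibitor of the pair, and the gap lies beyond the usual scatter of repeated measurements.

The next compound to be tested is compound 3 `O=C(/C=C/c1ccc(F)cc1)c1ccc(F)cc1`. It differs from compound 2 in one place, with fluoro in place of cyclohexyl on an aromatic carbon, para to a large group (fluoro in place of cyclohexyl on an aromatic carbon).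

Within the data shown here, no measured pair yet shows what a swap of this kind does in this assay, so any forecast is rough. Among the measured compounds shown here, the only guide is that compound 1 at 33000 nM and compound 2 at 74000 nM differ only modestly. No step beyond the scatter is therefore expected, with a slight lean towards a lower number. The expected step of a 1.2-fold lower number from compound 2 to compound 3 (0.09 log units; within the scatter) is small. Compound 3 is estimated at 60000 nM (range 20000 nM to 180000 nM).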

Compound 3, half-maximal inhibitory concentration: 22000 nM
Estimate against measurement, compound 3: 2.7-fold (0.44 log units) above; low and high end bracket the measured number.
By their numbers in this assay, from the lowest: compounds 3 and 1 (each within the scatter of the next); then compound 2.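

In this assay, the step from cyclohexyl to fluoro on an aromatic carbon, para to a large group, is a 3.4-fold lower number from compound 2 to compound 3 (0.53 log units; beyond the scatter), the first single change measured at this position. It shows that cyclohexyl is not needed here: the much smaller fluoro, with a single heavy atom and no ring, gives the lower number, so the stronger inhibitor of this pair. The second comparison, fluoro in place of phenoxy, is a 1.5-fold lower number from compound 1 to compound 3 (0.18 log units; within the scatter), so compound 1 and compound 3 cannot be told apart in this assay, and the two-ring phenoxy group shows no measurable gain over fluoro; nothing measured here explains either result.

The compounds shown leave open whether any group at this position could bring a much lower number, since cyclohexyl, phenoxy and fluoro all lack hydrogen-bond donors and none of them carries a net charge. An amine or a carboxylic acid in the same place would test that directly, and a methyl or a plain hydrogen would show how far the group can shrink before the number changes.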